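Benzyl thioether replacing the phenacyl group on compound 3

A few compounds are considered here, and "the series" means these few. Any claim that something is new, unique, unknown or untested is made for them only; others in the source may bear on it.

Compound 1 `Cc1nnc(SCc2ccccc2)n1N1C(=O)c2ccccc2C1=O`: in a functional assay on PC-3M cells (Homo sapiens) for cytotoxicity, read by MTT assay, with a stated time of 48 h (a lower number here means a stronger inhibitor, a higher number a weaker inhibitor), compound 1 gives > 200000 nM, which is a limit of the assay rather than a number.
Compound 2 `CCCc1nnc(SCc2ccccc2)n1N1C(=O)c2ccccc2C1=O`: compound 2 gives > 200000 nM, again a limit.
Compound 3 `COc1cc(-c2nnc(SCC(=O)c3ccc(C)cc3)n2N2C(=O)c3ccccc3C2=O)cc(OC)c1OC`: compound 3 gives 11700 nM.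

Within the data shown here, compound 3 therefore holds the only numeric value in this assay; the two other entries sit at the limit of > 200000 nM in this assay, at which 2 of the 3 values shown sit. Among the measured compounds shown here, the one step between measured compounds, from compound 1 to compound 2, reads a step that the two limits leave unreadable from compound 1 to compound 2 and says nothing about size.

Compound 4 `COc1cc(-c2nnc(SCc3ccccc3)n2N2C(=O)c3ccccc3C2=O)cc(OC)c1OC` differs from compound 3 by phenyl in place of (4-methylphenyl)carbonyl on a saturated chain carbon bound to a sulfur. For the measured compounds named here, no measured step covers this exchange. Going by the values given here, what the data offer is that compounds 1 and 2, which already carry the benzylsulfanyl group that enters in compound 4, both rest at the limit, while compound 3, with the ((4-methylphenyl)carbonyl)methyl)sulfanyl group, is the sole compound with a readable number. On that basis compound 4 is expected to be a weaker inhibitor than compound 3, with a real chance that only a limit is returned. The expected step from compound 3 to compound 4 is a 6.8-fold higher number from compound 3 to compound 4 (0.83 log units; beyond the scatter). Compound 4 is estimated at 80000 nM, within a range from 15000 nM to 300000 nM.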

Compound 4, half-maximal inhibitory concentration: > 200000 nM
Compound 4: a limit, no number; the forecaster's own chance of this, stated with the estimate: 55%; at least 2.5-fold (0.39 log units) between middle value and limit.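

Among these compounds, with the 3,4,5-trimethoxyphenyl group and the shared core held fixed, phenyl in place of (4-methylphenyl)carbonyl on a saturated chain carbon bound to a sulfur gives the first readable step in this assay: it is an at least 17-fold higher number from compound 3 to compound 4 (1.23 log units; beyond the scatter). Compound 4 carries a limit rather than a number, so this size is only a minimum, and compound 4 joins the other compounds at that limit: the limit of > 200000 nM in this assay, at which 3 of the 4 values shown sit. The benzylsulfanyl compounds therefore stay at the limit with 3,4,5-trimethoxyphenyl as well as with methyl or propyl, though the steps among these three compounds cannot be read.

Going by these compounds, it remains open whether the carbonyl or the 4-methyl group of the departing group matters more. A carboxylic acid or an amine on that chain carbon, or methyl or propyl in place of 3,4,5-trimethoxyphenyl with the (4-methylphenyl)carbonyl kept, could separate these contributions.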